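A few compounds are considered here, and "the series" means these few. Any claim that something is new, unique, unknown or untested is made for them only; others in the source may bear on it.

Compound 1 `Cc1ccnc2nc(-c3cccc(Cl)c3)cc(O)c12` and compound 2 `Oc1cc(-c2ccc3ccccc3c2)nc2ncccc12` share a bicyclic core carrying a hydroxyl and an aryl group, but the aryl groups differ, and the difference between the two cores is not broken down here. In a functional assay on U-251 cells (Homo sapiens) for antiproliferative activity (a lower number here means a stronger inhibitor of growth, a higher number a weaker inhibitor of growth), compound 1 gives 52.5 nM, while compound 2 gives 4370 nM, a far weaker inhibitor of growth.

Compound 3 `Cc1cc(C)c2c(O)cc(-c3cccc(Cl)c3)nc2n1` is compound 1 with one change: methyl in place of hydrogen on an aromatic carbon In this assay compound 3 gives 295 nM, and the step of a 5.6-fold higher number from compound 1 to compound 3 (0.75 log units; beyond the scatter) shows that adding this methyl weakened growth inhibition.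

Compound 4 `Cc1cnc2nc(-c3ccc4ccccc4c3)cc(O)c2c1` stands to compound 2 as compound 3 stands to compound 1, with the same kind of change: methyl in place of hydrogen on an aromatic carbon The two changes are not the same. The earlier methyl sits next to the ring nitrogen and meta to a methyl group, whereas the new one sits two atoms from the ring nitrogen, with no second methyl on the core.

For the measured compounds named here, with two compounds, the expectation rests on compound 3 alone, with its weakening step a 5.6-fold higher number from compound 1 to compound 3 (0.75 log units; beyond the scatter) as the one precedent. On that basis compound 4 is expected to show a step of a 2.1-fold higher number from compound 2 to compound 4 (0.31 log units; beyond the scatter). Compound 4 is therefore estimated at about 9000 nM, in a range from 3000 nM to 30000 nM.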

Compound 4, concentration for 50% growth inhibition: 468 nM
For compound 4 the middle estimate is 19-fold (1.28 log units) above the measured one; measured number outside the range, below it.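

In this assay the added methyl gives a 9.3-fold lower number from compound 2 to compound 4 (0.97 log units; beyond the scatter), so on this core the change strengthens growth inhibition, whereas on the core of compound 1 the same kind of change weakens it. Swapping hydrogen for methyl on an aromatic carbon therefore does not carry a fixed effect from one core to the other in this series, and even the direction of the step reverses: the same change on two cores in this assay, a 5.6-fold higher number (0.75 log units; beyond the scatter) from compound 1 to compound 3 and a 9.3-fold lower number (0.97 log units; beyond the scatter) from compound 2 to compound 4, 52-fold (1.72 log units) apart, beyond the scatter of two such steps This does not show why the two steps differ, since the methyls stand at different places, compound 3 carries a second methyl on its core, and the aryl groups are not the same, so a single pair on each core cannot separate these differences.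

On these data alone, it remains open whether a methyl two atoms from the ring nitrogen would also lower the number when paired with the aryl group of compound 1, and whether the placement seen in compound 3 would raise it when paired with the aryl group of compound 2. As far as these compounds go, it is also open whether an ethyl, a methoxy or an amine on that same carbon would follow the methyl of compound 4.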